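The source may hold more compounds than are shown below. What is called first, only, known or untested is meant among the compounds shown, and "the series" means these compounds.

Compound 3 `C[C@H]1CC[C@@H](C(=O)NCc2cc(-c3ccc(C(F)(F)F)nc3)ncn2)N1S(=O)(=O)c1ccc(F)cc1` gives the lowest number among three compounds in an assay on HEK293 cells for inhibition of transient receptor potential cation channel subfamily A member 1 (Homo sapiens), read by FLIPR and calcium flux, with a stated time of 20 min (on this read-out higher numbers stand for weaker inhibition and lower numbers for stronger inhibition), at 13 nM. Compound 1 `O=C(NCc1cc(-c2ccc(C(F)(F)F)nc2)ncn1)[C@@H]1CCCN1S(=O)(=O)c1ccc(F)cc1` gives 154 nM, and compound 2 `O=C(NCc1cc(-c2ccc(C(F)(F)F)nc2)ncn1)[C@@H]1CCCCN1S(=O)(=O)c1ccc(F)cc1` gives 2300 nM. Among the compounds with values here, the one single-point step measured so far, a 12-fold lower number from compound 1 to compound 3 (1.07 log units; beyond the scatter), put a methyl in place of hydrogen on a saturated ring carbon. Compound 4 `C[C@@H]1CC[C@@H](C(=O)NCc2cc(-c3ccc(C(F)(F)F)nc3)ncn2)N1S(=O)(=O)c1ccc(F)cc1` keeps that methyl but changes its arrangement: the two compounds have the same atoms and bonds and differ only in configuration as drawn: 1 of 2 stereo elements differ; a stereocentre at a saturated ring carbon is drawn S in compound 3 and R in compound 4. Within the data shown here, no measured step involves a change of configuration alone, so none bears directly on this move; the methyl step only shows that this ring position is sensitive. Compound 4 is therefore expected to lose some of the gain, with a step of a 6.2-fold higher number from compound 3 to compound 4 (0.79 log units; beyond the scatter). Compound 4 is estimated at 80 nM, within 15 nM to 400 nM.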

Compound 4, half-maximal inhibitory concentration in the transient receptor potential cation channel subfamily A member 1 assay: 239 nM
Compound 4: the middle estimate sits 3.0-fold (0.48 log units) below what was measured; the range from low to high includes it.
By their numbers in the transient receptor potential cation channel subfamily A member 1 assay, from the lowest: compound 3; then compounds 1 and 4 (each within the scatter of the next); then compound 2.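

In the transient receptor potential cation channel subfamily A member 1 assay, the methyl pays off in only one arrangement: drawn R at this ring carbon, it gives a 1.6-fold higher number from compound 1 to compound 4 (0.19 log units; within the scatter), while changing S to R alone gives an 18-fold higher number from compound 3 to compound 4 (1.26 log units; beyond the scatter). The same change of configuration also separates the compounds in a physicochemical assay for lipophilicity, at pH 7.4 (on this read-out higher numbers stand for higher lipophilicity and lower numbers for lower lipophilicity), where compound 3 gives 2.9 and compound 4 gives 4.3: the measured distribution coefficient of compound 3, 2.9, and of compound 4, 4.3, a number 1.40 log units higher (beyond the scatter).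

Two compounds cannot show whether this shift in lipophilicity is linked to the difference in inhibition. From the compounds shown here alone, it also remains open whether an ethyl group drawn S at this ring carbon would behave like the methyl.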